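The compounds below may be only part of what the source reports. "The series", "measured", "known", "first", "only" and "open" are said of these compounds alone.

Compound 1 `CCOC(=O)CN(Cc1ccccc1)c1nc(Nc2ccc(Cl)cc2)ncc1[N+](=O)[O-]` gives > 100000 nM in a functional assay on A549 cells (Homo sapiens) for antiproliferative activity, read by MTT assay, with a stated time of 48 h (on this read-out higher numbers stand for weaker inhibition and lower numbers for stronger inhibition), which is a limit of the assay and not a number.
Compound 2 `CCOC(=O)CN(Cc1ccccc1)c1nc(NCc2cccc(OC)c2)ncc1[N+](=O)[O-]` gives > 100000 nM in this assay, again a limit of the assay and not a number.

For the measured compounds named here, compound 2 therefore stands at the limit of this assay, and so does the one other value shown (the limit of > 100000 nM in this assay, at which 2 of the 2 values shown sit). Going by the values given here, the only measured step, a step that the two limits leave unreadable from compound 1 to compound 2, runs between two limits and cannot be read in size or direction.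

Compound 3 `CCOC(=O)CN(Cc1ccccc1)c1nc(NCc2ccccc2)ncc1[N+](=O)[O-]` differs from compound 2 by hydrogen in place of methoxy on an aromatic carbon. Among the compounds with values here, no measured step bears directly on this change, and the single step that exists is unreadable, so the data give no expected size or direction in this assay beyond the scatter. The starting point is itself a limit, and the change removes only a methoxy, so compound 3 is expected to remain at or around that limit, an expected step that the limit leaves unreadable from compound 2 to compound 3. The estimate for compound 3 is 150000 nM, with an expected range from 40000 nM to 600000 nM, most probably reported once more only as a limit.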

Compound 3, half-maximal inhibitory concentration: > 100000 nM
Compound 3 was reported as a limit; the forecaster's own chance of this, stated with the estimate: 85%; the middle value does not contradict the limit.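

Compound 3, like compound 1 and compound 2, is reported only as a limit of the assay and not a number, so no step among these three compounds can be read in size or direction: the limit of > 100000 nM in this assay, at which 3 of the 3 values shown sit.

What the compounds shown leave open is how any of these changes on the shared core would act in this assay, since none gives a value inside the measurable range.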